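Removing the Fluoro from Compound 1

The compounds below may be only part of what the source reports. "The series", "measured", "known", "first", "only" and "open" are said of these compounds alone.

Compound 1 `N#Cc1cc(-c2nc3ccc(F)cc3s2)ccc1N` gives 820 nM in a functional assay on MCF7 cells (Homo sapiens) for inhibition, with a stated time of 72 h (a higher number here means a weaker inhibitor of growth, a lower number a stronger inhibitor of growth), the highest of the three numbers measured; compound 2 `C[Si](C)(C)C#Cc1cc(-c2nc3ccc(F)cc3s2)ccc1N` gives 680 nM and compound 3 `C[Si](C)(C)C#Cc1cc(-c2nc3c(F)cccc3s2)ccc1N` gives 520 nM, both within the scatter of compound 1. For the measured compounds named here, the only step between measured compounds, a 1.2-fold lower number from compound 1 to compound 2 (0.08 log units; within the scatter), concerns a different part of the molecule. Compound 4 `N#Cc1cc(-c2nc3ccccc3s2)ccc1N` differs from compound 1 in hydrogen in place of fluoro on an aromatic carbon. Going by the values given here, no measured step touches the fused ring system directly; compounds 2 and 3, which carry the fluoro at different places on it, show values within the scatter of each other. A step of about a 1.1-fold higher number from compound 1 to compound 4 (0.04 log units; within the scatter) is therefore expected, nothing beyond the scatter. Compound 4 is estimated at 900 nM, with a range from 400 nM to 2000 nM.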

Compound 4, concentration for 50% growth inhibition: 580 nM
For compound 4 the middle estimate is 1.6-fold (0.19 log units) above the measured one, and the stated range covers the measured number.
By their numbers in this assay, from the lowest: compounds 3, 4, 2 and 1 (each within the scatter of the next).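

Hydrogen in place of fluoro gives a 1.4-fold lower number from compound 1 to compound 4 (0.15 log units; within the scatter) in this assay, the first measured step at this position on the six-membered aromatic ring. Compounds 1 and 4 therefore cannot be told apart here, so with the nitrile in place, the fluoro at this aromatic carbon shows no effect on growth inhibition that stands clear of the scatter. Nothing measured here offers an explanation for this result. Still open, from the compounds shown here alone, is whether a methoxy group or an amine on this same aromatic carbon would give a number beyond the scatter.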